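Methoxy addition on ether and thioether acetamide cores

The source may report more compounds than this note shows. Statements on the series, on what has been measured and on what is new or still open speak of the compounds shown alone.

Measured so far:
compound 1, `CC(=O)NCCOc1ccccc1`, 5500 nM
compound 2, `COc1cccc(OCCNC(C)=O)c1`, 67.6 nM
compound 3, `CC(=O)NCCSc1ccccc1`, 339 nM

All three numbers come from an assay on NIH3T3 cells for displacement of a labelled ligand from melatonin receptor type 1B (Homo sapiens), with a stated time of 90 min; a higher number here means a weaker inhibitor, a lower number a stronger inhibitor. Compound 1 gives 5500 nM in this assay, and the change to compound 2, (methoxy in place of hydrogen on an aromatic carbon), moves the number an 81-fold lower number from compound 1 to compound 2 (1.91 log units; beyond the scatter). Compound 3 sits between the two: in this assay compound 3 gives 339 nM, a higher number than compound 2 and a lower one than compound 1, both gaps beyond the scatter. The difference between the core of compound 1 and the core of compound 3 is not broken down here.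

Compound 4, `COc1ccc(SCCNC(C)=O)cc1`, is not yet measured. It differs from compound 3 by methoxy in place of hydrogen on an aromatic carbon. Among the compounds with values here, this is the same kind of change as the one from compound 1 to compound 2, but not the same: in compound 2 the methoxy sits meta to a group of 7 heavy atoms, in compound 4 it sits para to a group of 7 heavy atoms. Within the data shown here, the only measured step with this change is an 81-fold lower number from compound 1 to compound 2 (1.91 log units; beyond the scatter), made on the core of compound 1 at a different place on the ring. Among the measured compounds shown here, no compound with a methoxy at the place used in compound 4 has been measured, so the step cannot be carried over in full. Compound 4 is expected to give a lower number than compound 3 in this assay, with an estimated step of a 3.4-fold lower number from compound 3 to compound 4 (0.53 log units; beyond the scatter), smaller than the measured step because the step of an 81-fold lower number from compound 1 to compound 2 (1.91 log units; beyond the scatter) was made with the methoxy at a different place on the ring and on a different core. For compound 4 the estimate is 100 nM, with a range from 20 nM to 500 nM.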

Compound 4, inhibition constant: 2400 nM
Beside the measured number, compound 4's estimate is 24-fold (1.38 log units) below it; the measured number lies above the stated range.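

In this assay, methoxy in place of hydrogen on an aromatic carbon gives a 7.1-fold higher number from compound 3 to compound 4 (0.85 log units; beyond the scatter), so the direction of this change does not hold from one core to the other: the same change on two cores in this assay, an 81-fold lower number (1.91 log units; beyond the scatter) from compound 1 to compound 2 and a 7.1-fold higher number (0.85 log units; beyond the scatter) from compound 3 to compound 4, 580-fold (2.76 log units) apart, beyond the scatter of two such steps

The step measured on the core of compound 1 therefore cannot be carried over to the core of compound 3, either in size or in direction. These two pairs do not show whether core or ring place accounts for the gap: the methoxy of compound 4 sits para to a group of 7 heavy atoms, the methoxy of compound 2 sits at a different place on the ring, and the cores differ as well, so both vary at once.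

Open, from the compounds shown here alone, is whether a methoxy at the place used in compound 2 would lower the number on the core of compound 3, and whether a methoxy at the place used in compound 4 would raise it on the core of compound 1, two pairings that would separate place from core. Also open, going by these compounds, is how a hydroxyl or a chlorine atom at these ring places, or a longer chain in place of the acetyl group, would read in this assay.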